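Swapping the sulfonyl aryl group of compound 1

This account rests on a few compounds, and the source may have more. Where it says the series, first, only, none or still open, it means among the compounds named here.

In an ADME assay on the whole organism (Rattus norvegicus, strain Sprague-Dawley) for pharmacokinetics, read by LC-MS, with a stated time of 30 min, at a dose of 1 mg/kg by the intravenous route (on this read-out higher numbers stand for fast clearance and lower numbers for slow clearance), compound 1 (`N#Cc1ccc(O[C@H]2CN(S(=O)(=O)c3ccc(Cl)cc3Cl)C[C@]2(O)CO)cc1F`) gives 1350 mL/min/kg and compound 2 (`N#Cc1ccc(O[C@H]2CN(S(=O)(=O)c3ccc(Cl)cc3)C[C@@]2(O)CO)cc1F`) gives 1540 mL/min/kg as its clearance, so these two numbers lie within the usual scatter of each other and compound 1 has no clear place apart from compound 2. Compound 3 (`N#Cc1ccc(O[C@H]2CN(S(=O)(=O)c3ccc(Cl)cn3)C[C@]2(O)CO)cc1F`) carries 5-chloropyridin-2-yl in place of 2,4-dichlorophenyl on a sulfonyl sulfur. Among the measured compounds shown here, no measured pair shows this swap alone, so the expected step of a 1.0-fold lower number from compound 1 to compound 3 (0.02 log units; within the scatter) is none beyond the scatter in this assay and no direction is favoured. For compound 3 the estimated clearance is 1300 mL/min/kg with an expected range from 700 mL/min/kg to 2500 mL/min/kg on this estimate.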

Compound 3, clearance: 150 mL/min/kg
Estimate against measurement, compound 3: 8.7-fold (0.94 log units) above; measured number outside the range, below it.
By their numbers in this assay, from the lowest: compound 3; then compounds 1 and 2 (each within the scatter of the next).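

On the sulfonyl sulfur, replacing 2,4-dichlorophenyl with 5-chloropyridin-2-yl gives a 9.0-fold lower number from compound 1 to compound 3 (0.95 log units; beyond the scatter) in this assay, so clearance in this series clearly depends on this aryl group. This single swap both brings in a ring nitrogen and removes a chlorine, and the data do not separate the two changes. Nothing measured here explains the step. It remains open which of the two changes accounts for the step. As far as these compounds go, it also remains open whether another ring on the sulfur, such as pyrimidin-2-yl, would give a similar clearance.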